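Trading the Fluorophenyl Arm of Compound 1 for Trifluoromethylphenyl

The source may hold more compounds than are shown below. What is called first, only, known or untested is meant among the compounds shown, and "the series" means these compounds.

Compound 1 `Oc1cccc(-c2cc(-c3ccc(F)cc3)cc(-c3ccccc3O)n2)c1` was tested in a functional assay on HCT-15 cells (Homo sapiens) for inhibition; on this read-out higher numbers stand for weaker inhibition and lower numbers for stronger inhibition. Compound 1 shows only a limit there, > 50000 nM. Compound 2 `Oc1ccc(-c2cc(-c3ccc(F)cc3)cc(-c3ccccc3O)n2)cc1` likewise gives only a limit, > 50000 nM. Going by the values given here, compound 3 `Oc1ccc(-c2cc(-c3ccc(F)cc3)cc(-c3cccc(O)c3)n2)cc1` gives 5020 nM, so compound 3 is the only one with a readable number, as the limit of > 50000 nM in this assay, at which 2 of the 3 values shown sit, holds the other two. The measured steps, an at least 9.9-fold lower number from compound 1 to compound 3 (0.99 log units; beyond the scatter) and an at least 9.9-fold lower number from compound 2 to compound 3 (0.99 log units; beyond the scatter), each move a hydroxyphenyl group, while a step that the two limits leave unreadable from compound 1 to compound 2. None of them touches the third arm. Compound 4 `Oc1cccc(-c2cc(-c3cccc(C(F)(F)F)c3)cc(-c3ccccc3O)n2)c1` differs from compound 1 in exactly that arm: 3-(trifluoromethyl)phenyl in place of 4-fluorophenyl on an aromatic carbon. Among the compounds with values here, no measured step bears on this change, and no shift beyond the scatter is expected. Compound 4 is estimated at 50000 nM, between 10000 nM and 200000 nM, meaning a number no higher from compound 1 to compound 4 (the limit leaves the size open), most likely again only a limit.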

Compound 4, half-maximal inhibitory concentration: 6460 nM
Compound 4: middle estimate off by 7.7-fold (0.89 log units), on the high side; measured number below the stated range.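

The third arm is not a silent position: in this assay, the swap to 3-(trifluoromethyl)phenyl brings an at least 7.7-fold lower number from compound 1 to compound 4 (0.88 log units; beyond the scatter). Until now, only moving a hydroxyphenyl group had given a readable number, whereas compound 4 keeps the 2-hydroxyphenyl and 3-hydroxyphenyl arms of compound 1. The full size of this step stays open because compound 1 holds only a limit: the limit of > 50000 nM in this assay, at which 2 of the 4 values shown sit.

Still open, as far as these compounds go, is whether the trifluoromethyl group itself or its place on the ring carries the step. From the compounds shown here alone, the effect of an amine or a carboxylic acid on this arm also remains open.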